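The compounds below may be only part of what the source reports. "The series", "measured", "known", "first", "only" and "open" are said of these compounds alone.

Compound 1 `O=c1c2cc(-c3ccc(Cl)cc3)cn2ncn1-c1ccc(N2CC(O)C2)nc1` is the stronger of the two compounds measured in an assay on HEK293 cells for displacement of a labelled ligand from melanin-concentrating hormone receptor 1 (Homo sapiens), read by scintillation counting; a lower number here means a stronger inhibitor, a higher number a weaker inhibitor: in that assay compound 1 gives 15 nM. Compound 2 `O=c1c2cc(-c3ccc(Cl)cn3)cn2ncn1-c1ccc(N2CC[C@@H](O)C2)nc1` carries a chloropyridinyl group and a hydroxypyrrolidinyl ring where compound 1 has chlorophenyl and hydroxyazetidinyl, and in this assay compound 2 gives 124 nM; since compound 2 differs from compound 1 in two places at once, no single change can be credited with the gap between them. Compound 3 `O=c1c2cc(-c3ccc(Cl)cc3)cn2ncn1-c1ccc(N2CCC(O)CC2)nc1` keeps the chlorophenyl side of compound 1 and differs only at the amine on the pyridine: 4-hydroxypiperidin-1-yl in place of 3-hydroxyazetidin-1-yl on an aromatic carbon. For the measured compounds named here, no measured pair isolates a change of this kind. Given that compound 1 sits at 15 nM and the wider ring is the only alteration, a modest loss is expected, a 2.3-fold higher number from compound 1 to compound 3 (0.37 log units; beyond the scatter). Compound 3 is therefore estimated at 35 nM in this assay, within a range from 10 nM to 120 nM.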

Compound 3, inhibition constant: 12 nM
Compound 3: middle estimate off by 2.9-fold (0.46 log units), on the high side; the measured number falls inside the stated range.
By their numbers in this assay, from the lowest: compounds 3 and 1 (each within the scatter of the next); then compound 2.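

In this assay, 4-hydroxypiperidin-1-yl in place of 3-hydroxyazetidin-1-yl gives a 1.3-fold lower number from compound 1 to compound 3 (0.10 log units; within the scatter), so with the chlorophenyl side held constant, the two compounds cannot be told apart. This position, on an aromatic carbon next to the ring nitrogen and para to a large group, therefore tolerates both the four-membered and the six-membered ring carrying a hydroxyl group, with no measurable penalty for the larger ring. No measurement is available here to explain this tolerance.

Going by these compounds, it remains open whether the hydroxyl group itself matters, which a plain piperidin-1-yl or a morpholin-4-yl group at this position would test. The effect of the five-membered ring also remains unresolved, as a hydroxypyrrolidinyl group paired with the chlorophenyl side would be needed to separate it from the chloropyridinyl change.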